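Benzyloxycarbonyl in place of bromo: an expected step

This account rests on a few compounds, and the source may have more. Where it says the series, first, only, none or still open, it means among the compounds named here.

In a functional assay on MCF7 cells (Homo sapiens) for antiproliferative activity, read by MTT assay, with a stated time of 48 h (on this read-out higher numbers stand for weaker inhibition and lower numbers for stronger inhibition), compound 1 `Fc1ccc(-c2nn(-c3ccccc3)cc2-c2nc3ccccc3[nH]2)cc1` gives 3200 nM and compound 2 `Fc1ccc(-c2nn(-c3ccccc3)cc2-c2nc3cc(Cl)ccc3[nH]2)cc1` gives 2230 nM while compound 3 `Fc1ccc(-c2nn(-c3ccccc3)cc2-c2nc3cc(Br)ccc3[nH]2)cc1` gives 3210 nM and so stands within the scatter of both. Compound 4 `O=C(OCc1ccccc1)c1ccc2[nH]c(-c3cn(-c4ccccc4)nc3-c3ccc(F)cc3)nc2c1` carries benzyloxycarbonyl in place of bromo on an aromatic carbon as its change from compound 3. The measured steps bearing on it are a 1.0-fold higher number from compound 1 to compound 3 (0.00 log units; within the scatter) and a 1.4-fold higher number from compound 2 to compound 3 (0.16 log units; within the scatter) with a 1.4-fold lower number from compound 1 to compound 2 (0.16 log units; within the scatter) alongside them, all within the scatter. They cover only hydrogen, chloro and bromo, so they give no measure for a group of this size. No step beyond the scatter is therefore expected in this assay though confidence is low: the estimated move is a 1.3-fold lower number from compound 3 to compound 4 (0.11 log units; within the scatter) in a wide band. For compound 4 the expected value is estimated at 2500 nM with a range from 700 nM to 9000 nM as its bounds.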

Compound 4, half-maximal inhibitory concentration: 9240 nM
Compound 4: middle estimate off by 3.7-fold (0.57 log units), on the low side; measured number outside the range, above it.
By their numbers in this assay, from the lowest: compounds 2, 1 and 3 (each within the scatter of the next); then compound 4.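

For the compounds shown here, at this position, this assay gives the first steps beyond the scatter: a 2.9-fold higher number from compound 3 to compound 4 (0.46 log units; beyond the scatter), a 4.1-fold higher number from compound 2 to compound 4 (0.62 log units; beyond the scatter) and a 2.9-fold higher number from compound 1 to compound 4 (0.46 log units; beyond the scatter). Hydrogen, chloro and bromo stayed within the scatter of one another, so the position does not treat all substituents alike, and benzyloxycarbonyl weakens inhibition against all three. No measurement available here accounts for this rise.

As far as these compounds go, whether the carbonyl or the benzyl part carries the rise remains open. A carboxylic acid or a methyl ester in place of benzyloxycarbonyl would separate the two.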